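A New Group on the Ring Nitrogen of Compound 1

This account rests on a few compounds, and the source may have more. Where it says the series, first, only, none or still open, it means among the compounds named here.

In an ADME assay on HeLa cells (Homo sapiens) for cytotoxicity, read by MTT assay, with a stated time of 96 h (on this read-out higher numbers stand for weaker inhibition and lower numbers for stronger inhibition), compound 1 (`COc1ccc(CN2CCN(c3ccc(C4CC(c5ccc([N+](=O)[O-])o5)=NO4)cc3)CC2)cn1`) gives > 50000 nM as a limit of the assay, not a number. Compound 2 (`O=[N+]([O-])c1ccc(C2=NOC(c3ccc(-c4ccccn4)cc3)C2)o1`) gives > 50000 nM as a limit too. The record so far is the limit of > 50000 nM in this assay, at which 2 of the 2 values shown sit, and no more, so compound 1 stands at that limit without a number of its own. Compound 3 (`CC(C)(C)OC(=O)N1CCN(c2ccc(C3CC(c4ccc([N+](=O)[O-])o4)=NO3)cc2)CC1`) keeps the core of compound 1 but carries tert-butoxycarbonyl in place of (6-methoxypyridin-3-yl)methyl on an amine nitrogen in a ring. Within the data shown here, no measured pair shows what such a change does, so no step beyond the usual scatter is expected in this assay and neither direction is favoured. The estimated step is a number no higher from compound 1 to compound 3 (the limit leaves the size open) in this reading. Compound 3 is estimated at 50000 nM with an expected range from 20000 nM to 100000 nM and may well come out only as a limit.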

Compound 3, half-maximal inhibitory concentration: > 50000 nM
Compound 3 gave a limit, no number; the forecaster's own chance of this, stated with the estimate: 70%; the middle value lies on the limit itself.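

In this assay, among these compounds, compound 3 gives > 50000 nM, a limit of the assay and not a number, so no step from compound 1 to compound 3 can be read. The compounds shown leave open what this change on the ring nitrogen does to the read-out, since all of them rest at one limit: the limit of > 50000 nM in this assay, at which 3 of the 3 values shown sit.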